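Swapping thiophen-2-yl for 2,4,6-trimethylphenyl

The source may hold more compounds than are shown below. What is called first, only, known or untested is meant among the compounds shown, and "the series" means these compounds.

Compound 1 `Cn1c(=O)c(=O)n(C2CCCC2)c2nc(N/N=C/c3ccccc3)ncc21`: > 100000 nM (a limit of the assay, not a number)
Compound 2 `Cn1c(=O)c(=O)n(C2CCCC2)c2nc(N/N=C/c3cccs3)ncc21`: 52600 nM

Among the measured compounds shown here, in a functional assay on HCT-116 cells (Homo sapiens) for antiproliferative activity, read by MTT assay (on this read-out higher numbers stand for weaker inhibition and lower numbers for stronger inhibition), compound 2 gives 52600 nM, the only exact number so far. Compound 3 `Cc1cc(C)c(/C=N/Nc2ncc3c(n2)n(C2CCCC2)c(=O)c(=O)n3C)c(C)c1` has 2,4,6-trimethylphenyl in place of thiophen-2-yl on a carbon with a double bond to nitrogen. For the measured compounds named here, one measured step bears on this: an at least 1.9-fold lower number from compound 1 to compound 2 (0.27 log units; that floor lies within the scatter), whose floor lies within the scatter. Compound 3 again carries a six-membered aromatic ring of carbon only, so a slightly higher number is expected, hardly beyond the scatter. The expected change is a 1.3-fold higher number from compound 2 to compound 3 (0.12 log units; within the scatter). For compound 3 the estimated value is 70000 nM, with an expected range of 25000 nM to 100000 nM.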

Compound 3, half-maximal inhibitory concentration: 7920 nM
For compound 3 the middle estimate is 8.8-fold (0.95 log units) above the measured one; the measured number lies below the stated range.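

In this assay, the group on the carbon with a double bond to nitrogen matters more than the first pair could show: the result is a 6.6-fold lower number from compound 2 to compound 3 (0.82 log units; beyond the scatter), and also an at least 12-fold lower number from compound 1 to compound 3 (1.10 log units; beyond the scatter). A six-membered aromatic ring of carbon only is therefore not weak in itself, since phenyl and 2,4,6-trimethylphenyl both have one and still differ beyond the scatter. The second step is only a floor, as compound 1 stands at a limit of the assay: the limit of > 100000 nM in this assay, at which 1 of the 3 values shown sits.

On these data alone, whether every methyl of 2,4,6-trimethylphenyl is needed remains open. So does the effect of an amine or a carboxylic acid on that phenyl ring.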